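Aryl group variation on the shared core

The compounds below may be only part of what the source reports. "The series", "measured", "known", "first", "only" and "open" are said of these compounds alone.

Measured compounds:
compound 1 `CC(=O)c1ccc(-c2cn3ccnc3c(-c3ccc4ncn(C5CCCCC5)c4c3)n2)cc1`: 6.33%
compound 2 `COc1ccccc1-c1cn2ccnc2c(-c2ccc3ncn(C4CCCCC4)c3c2)n1`: 7.73%

In a functional assay on SN12C cells (Homo sapiens) for inhibition, read by sulforhodamine B assay, with a stated time of 48 h, tested at 10 uM (on this read-out lower numbers stand for less inhibition and higher numbers for more inhibition at the one concentration tested (going by the name of the read-out)), compound 2 gives 7.73% and stands level with compound 1, the step of a number 1.4 percentage points higher from compound 1 to compound 2 (within the scatter) lying within the scatter. Compound 3 `Fc1ccccc1-c1cn2ccnc2c(-c2ccc3ncn(C4CCCCC4)c3c2)n1` differs from compound 2 by fluoro in place of methoxy on an aromatic carbon. Among the compounds with values here, the one measured step that bears on this, the exchange of the whole aryl group between compound 1 and compound 2, was small. A step of a number 0.7 percentage points lower from compound 2 to compound 3 (within the scatter) in this assay is therefore expected, none beyond the scatter. Compound 3 is estimated at 7%, with a range from -3% to 20%.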

Compound 3, a percentage reported as inhibition, at one concentration (the size of the read-out at that concentration, not a potency): 10.1%
Compound 3: middle estimate off by 3.1 percentage points, on the low side, within the range that was stated.
By their numbers in this assay, from the lowest: compounds 1, 2 and 3 (each within the scatter of the next).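

In this assay, fluoro in place of methoxy on this aromatic carbon, ortho to a large group, gives a number 2.4 percentage points higher from compound 2 to compound 3 (within the scatter), so this smaller exchange also leaves the read-out level. The wider exchange of the whole aryl group gives a number 3.8 percentage points higher from compound 1 to compound 3 (within the scatter), which places 2-fluorophenyl, 2-methoxyphenyl and the 4-acetylphenyl group of compound 1 within the scatter of one another. No measurement at hand offers an explanation for this. As far as these compounds go, whether an amine or a carboxylic acid at this place on the ring would give a step beyond the scatter remains open.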